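One added methoxy: from compound 2 to compound 4

A few compounds are considered here, and "the series" means these few. Any claim that something is new, unique, unknown or untested is made for them only; others in the source may bear on it.

Measured so far in a functional assay on HCT-116 cells (Homo sapiens) for inhibition, read by MTT assay, with a stated time of 72 h, in the presence of a further agent that is not named here (on this read-out higher numbers stand for an effect only at larger amounts of compound and lower numbers for an effect already at smaller amounts), are these compounds:
Compound 1 `O=C(Nc1cc(Cl)nc(Cl)c1)Nc1cc2ccc(Br)cn2n1` gives 5260 nM
Compound 2 `O=C(Nc1cc(Cl)cc(Cl)c1)Nc1cc(Cl)nc(Cl)c1` gives 11400 nM
Compound 3 `O=C(Nc1ccnc(Cl)c1)Nc1cc(Cl)nc(Cl)c1` gives 16100 nM

Compound 2 holds the second highest of the three numbers. It lies within the scatter of compound 3 and beyond the scatter of compound 1, whose number is lower. Compound 4 `COc1c(Cl)cc(NC(=O)Nc2cc(Cl)nc(Cl)c2)cc1Cl` is still unmeasured and differs from compound 2 by methoxy in place of hydrogen on an aromatic carbon which is methoxy in place of hydrogen on an aromatic carbon. For the measured compounds named here, no measured step shows such a change, so from compound 2 at 11400 nM no step beyond the scatter is expected in this assay in either direction. The estimated change is a 1.3-fold lower number from compound 2 to compound 4 (0.10 log units; within the scatter) and it stays within the scatter. Compound 4 is expected at 9000 nM (estimated range 3500 nM to 23000 nM).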

Compound 4, half-maximal effective concentration: 41500 nM
Compound 4: the middle estimate sits 4.6-fold (0.66 log units) below what was measured, and the stated range ends below it.
By their numbers in this assay, from the lowest: compound 1; then compounds 2 and 3 (each within the scatter of the next); then compound 4.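

In this assay, for the compounds shown here, methoxy in place of hydrogen on the aromatic carbon ortho to two chloro groups and para to a large group gives a 3.6-fold higher number from compound 2 to compound 4 (0.56 log units; beyond the scatter), the first step that can be read in this set. This position is therefore not indifferent to substitution: here the added methoxy moves the number upward, so an effect appears only at larger amounts of compound. Nothing at hand accounts for this step.

Methoxy is the only group shown at this carbon besides hydrogen. On these data alone, whether a hydroxy, an amine or a longer alkoxy chain there would move the number the same way stays open.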